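Chain extension on the thiophene amide series

The source may report more compounds than this note shows. Statements on the series, on what has been measured and on what is new or still open speak of the compounds shown alone.

Compound 2 `CCCCCCCCCCCCNC(=O)[C@@H](NC(=O)c1cccs1)[C@@H](C)O` carries a thiophen-2-yl carbonyl on the amino group of the shared core. In a functional assay on A-431 cells (Homo sapiens) for cytotoxicity, read by MTT assay, with a stated time of 48 h (on this read-out higher numbers stand for weaker inhibition and lower numbers for stronger inhibition), compound 2 gives 16600 nM. Among the three measured compounds it stands second highest on the numbers: compound 1 `CCCCCCCCCCCCCCNC(=O)[C@@H](N)[C@@H](C)O`, the free amine on a longer chain, gives 14600 nM in this assay, and compound 3 `CCCCCCCCCCCCNC(=O)[C@@H](NC(=O)c1cc2ccccc2o1)[C@@H](C)O` gives 20000 nM in this assay. All three numbers lie within the scatter of one another, so no order among them can be read from these data.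

Compound 4 `CCCCCCCCCCCCCCNC(=O)[C@@H](NC(=O)c1cccs1)[C@@H](C)O` differs from compound 2 by ethyl in place of hydrogen on a saturated chain carbon, ten or more bonds along the chain from an amide-type nitrogen. Within the data shown here, no measured step isolates this change. Among the measured compounds shown here, the only measured single-point step, a 1.2-fold higher number from compound 2 to compound 3 (0.08 log units; within the scatter), concerns the carbonyl substituent and not the chain. Compound 1 and compound 2 differ in both the chain and the substituent on the amine, and their two values sit within the scatter of each other, which gives no sign that chain length moves the number in this assay. The step of a 1.0-fold lower number from compound 2 to compound 4 (0.02 log units; within the scatter) is therefore expected to be none beyond the scatter. Compound 4 is estimated at 16000 nM in this assay, with a range from 8000 nM to 33000 nM.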

Compound 4, half-maximal inhibitory concentration: 26500 nM
Compound 4: middle estimate off by 1.7-fold (0.22 log units), on the low side; measured number inside the range.
By their numbers in this assay, from the lowest: compounds 1, 2, 3 and 4 (each within the scatter of the next).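

In this assay, ethyl in place of hydrogen on a saturated chain carbon, ten or more bonds along the chain from an amide-type nitrogen, now has a measured step of its own with the thiophen-2-yl carbonyl held fixed: a 1.6-fold higher number from compound 2 to compound 4 (0.20 log units; within the scatter) and so the chain change shows no effect that can be told from the scatter. The series also gains its first measured step at the amine nitrogen with the chain held fixed, (thiophen-2-yl)carbonyl in place of hydrogen, and this step, a 1.8-fold higher number from compound 1 to compound 4 (0.26 log units; within the scatter) likewise gives no readable difference between the acylated compound and the free amine. Nothing measured here bears on why either step is as small as it is.

Going by these compounds, whether a chain much longer or much shorter than those in compound 2 and compound 4 would give a step beyond the scatter stays open. Also open is whether a carbonyl substituent carrying a carboxylic acid or an amine, in place of thiophen-2-yl or 1-benzofuran-2-yl, would separate from the four compounds shown, none of which stands apart from the others in this read-out.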